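The compounds below may be only part of what the source reports. "The series", "measured", "known", "first", "only" and "open" are said of these compounds alone.

Measured compounds:
compound 1 `CC(O)(C(=O)Nc1ccc(S(=O)(=O)c2ccccc2)c(F)c1)C(F)(F)F` with 1800 nM in a functional assay (Cavia porcellus) with sulfonylurea receptors; K-ATP channels (Homo sapiens) as the target; a higher number here means a weaker inhibitor, a lower number a stronger inhibitor
compound 2 `CC(O)(C(=O)Nc1ccc(C#N)c(Sc2ccccc2)c1)C(F)(F)F` with 8300 nM
compound 3 `CC(O)(C(=O)Nc1ccc(S(=O)(=O)c2cccc(O)c2)cc1)C(F)(F)F` with 18000 nM

Compound 1 has the lowest number of the three in this assay; compound 2 and compound 3 both lie above it, and both gaps are wider than the usual scatter. No pair among these three differs in only one place, so no single step is known from which a trend could be read.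

Compound 4 `CC(O)(C(=O)Nc1ccc(S(=O)(=O)c2ccccc2)c(Cl)c1)C(F)(F)F` differs from compound 1 by chloro in place of fluoro on an aromatic carbon. Among the measured compounds shown here, no step of this kind is available among the measured compounds, so the expectation rests on compound 1 alone, with its 1800 nM. A step from compound 1 to compound 4 of a 1.4-fold lower number from compound 1 to compound 4 (0.14 log units; within the scatter) is expected, within the scatter. Compound 4 is estimated at 1300 nM, with a range from 450 nM to 3800 nM.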

Compound 4, half-maximal inhibitory concentration: 2200 nM
The estimate for compound 4 lay 1.7-fold (0.23 log units) below the measured number; the measured number falls inside the stated range.
By their numbers in this assay, from the lowest: compounds 1 and 4 (each within the scatter of the next); then compound 2; then compound 3.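

In this assay, among the compounds shown here, chloro in place of fluoro on this aromatic carbon gives a 1.2-fold higher number from compound 1 to compound 4 (0.09 log units; within the scatter), the first step in the set that differs in one place. At this position, ortho to a group of 9 heavy atoms, the two halogens therefore cannot be told apart. No measurement shown explains this result.

As far as these compounds go, whether a methyl, a methoxy or an amine on this carbon would read the same remains open. So does whether the same exchange would give a similar step on the core of compound 2.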